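Swapping a Hexyl Chain for a Chlorophenoxy Group

The compounds below may be only part of what the source reports. "The series", "measured", "known", "first", "only" and "open" are said of these compounds alone.

Of the compounds shown here, three have been tested in an assay on isolated protein for inhibition of Aromatase (Homo sapiens), read by fluorescence and colorimetric assay, with a stated time of 30 min; on this read-out higher numbers stand for weaker inhibition and lower numbers for stronger inhibition. Compound 1 `N#Cc1ccc(C(c2ccc(C#N)cc2)n2cc(COc3ccccc3)nn2)cc1` gives 11000 nM in this assay, compound 2 `N#Cc1ccc(OCc2cn(C(c3ccc(C#N)cc3)c3ccc(C#N)cc3)nn2)cc1` gives 4640 nM, and compound 3 `CCCCCCCc1cn(C(c2ccccc2)c2ccccc2)nn1` gives 19400 nM. Compound 3 therefore carries the highest of the three numbers; its gap to compound 1 lies within the scatter, while its gap to compound 2 lies beyond it.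

Among the compounds with values here, the only single-point step measured so far is a 2.4-fold lower number from compound 1 to compound 2 (0.37 log units; beyond the scatter). Compound 4 `Clc1ccc(OCc2cn(C(c3ccccc3)c3ccccc3)nn2)cc1` is made from compound 3 by a different change: 4-chlorophenoxy in place of hexyl on a saturated chain carbon bound to an aromatic carbon. Compound 1 and compound 3 differ in more than one place, so their near-equal values can only hint that this kind of exchange need not move the number much. Within the data shown here, no measured step addresses a chloro substituent at all.

With that thin basis, a change in this assay of no more than the scatter is expected, leaning slightly toward a lower number, giving a 1.6-fold lower number from compound 3 to compound 4 (0.21 log units; within the scatter). Compound 4 is thus estimated at 12000 nM, within a range from 4000 nM to 35000 nM.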

Compound 4, half-maximal inhibitory concentration: 13400 nM
Estimate against measurement, compound 4: 1.1-fold (0.05 log units) below, within the range that was stated.
By their numbers in this assay, from the lowest: compound 2; then compounds 1, 4 and 3 (each within the scatter of the next).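

In this assay, putting 4-chlorophenoxy in place of hexyl on a saturated chain carbon bound to an aromatic carbon gives a 1.4-fold lower number from compound 3 to compound 4 (0.16 log units; within the scatter), so the two compounds cannot be told apart on this read-out. The earlier compounds shown here could only hint at this, since compound 1 and compound 3 differ in more than one place, whereas this pair differs in one place alone and shows that a plain hexyl chain and a larger group carrying a six-membered aromatic ring, an oxygen and a chlorine can read the same at this position. That finding holds for this single pair, and no supporting measurement is available to explain it.

Going by these compounds, whether the chlorine has any influence of its own, apart from the phenoxy ring that carries it, remains open, as does whether a nitrile on that ring would lower the number on this core as it did between compound 1 and compound 2. Also open, on these data alone, is how a strongly different group at the same place, such as an amine or a carboxylic acid, would read.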